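This account rests on a few compounds, and the source may have more. Where it says the series, first, only, none or still open, it means among the compounds named here.

Measured in a functional assay on HT-29 cells (Homo sapiens) for inhibition, read by MTT assay; on this read-out higher numbers stand for weaker inhibition and lower numbers for stronger inhibition:

- Compound 1 `COc1ccc(/C=C2\c3cc(OC)c(OC)c(OC)c3CC[C@@H]2O)cc1F`: 3 nM
- Compound 2 `COc1ccc(/C=C2\c3cc(OC)c(OC)c(OC)c3CC[C@@H]2O)cc1C(N)=O`: 550 nM
- Compound 3 `COc1ccc(/C=C2\c3cc(OC)c(OC)c(OC)c3CC[C@H]2O)cc1F`: 220 nM

Compound 3, at 220 nM, holds the second highest of the three numbers in this assay. It lies below compound 2 and well above compound 1. The step of a 73-fold higher number from compound 1 to compound 3 (1.87 log units; beyond the scatter) is tied to the fact that compounds 1 and 3 differ only in the configuration as drawn, so it bears on the starting level rather than on the group now exchanged.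

Compound 4 `COc1ccc(/C=C2\c3cc(OC)c(OC)c(OC)c3CC[C@H]2O)cc1[N+](=O)[O-]` keeps the configuration of compound 3 and carries nitro in place of fluoro on an aromatic carbon, ortho to a methoxy group: nitro in place of fluoro on an aromatic carbon.

Within the data shown here, the nearest precedent is another replacement of fluoro at this place, a 180-fold higher number from compound 1 to compound 2 (2.26 log units; beyond the scatter). That step was large, but it brought in carbamoyl rather than nitro and was measured on the other configuration. A rise in the same direction is therefore expected, though a smaller one.

The expected change is a 5.5-fold higher number from compound 3 to compound 4 (0.74 log units; beyond the scatter). For compound 4 the estimated value is 1200 nM, with an expected range from 200 nM to 7000 nM.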

Compound 4, half-maximal inhibitory concentration: > 10000 nM
Compound 4 gave a limit, no number; the forecaster's own chance of this, stated with the estimate: 10%; at least 8.3-fold (0.92 log units) between middle value and limit.
By their numbers in this assay, from the lowest: compound 1; then compound 3; then compound 2. At a limit, above all of these: compound 4.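

In this assay compound 4 gives only a limit, > 10000 nM, and not a number. Nitro in place of fluoro, on an aromatic carbon ortho to a methoxy group, gives an at least 45-fold higher number from compound 3 to compound 4 (1.65 log units; beyond the scatter), so this position can still lose much inhibition even on a configuration that already starts from a high number. Taken with a 180-fold higher number from compound 1 to compound 2 (2.26 log units; beyond the scatter), this means that both replacements of fluoro shown, carbamoyl on one configuration and nitro on the other, raise the number by a large step.

The compounds shown leave open how a small group such as an amine or a methyl at this place would read against fluoro. Also open, on these data alone, is how large the nitro step would be on the configuration of compound 1, which gives 3 nM.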